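Aryl carbamate variation: compound 2 to compound 3

The source may hold more compounds than are shown below. What is called first, only, known or untested is meant among the compounds shown, and "the series" means these compounds.

Measured compounds:
compound 1 `COc1nc(C)c(Nc2nc(Cl)cn([C@H](COC(=O)c3ccccc3)C3CC3)c2=O)cc1C` — 1.5 nM
compound 2 `COc1nc(C)c(Nc2nc(Cl)cn([C@H](COC(=O)Nc3ccccc3Cl)C3CC3)c2=O)cc1C` — 1.5 nM

In an assay on frontal cortex for displacement of a labelled ligand from corticotropin-releasing factor receptor 1 (Rattus norvegicus), with a stated time of 2 h (on this read-out lower numbers stand for stronger inhibition and higher numbers for weaker inhibition), compound 1 gives 1.5 nM and compound 2 gives 1.5 nM. The two values are level at the digits printed, so compound 2 stands within the scatter of compound 1 and no order can be set between them. Within the data shown here, the one measured step, no change at the digits printed from compound 1 to compound 2 (within the scatter), covers the exchange of (2-chlorophenyl)amino in place of phenyl on a carbonyl carbon and shows nothing beyond the scatter.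

Compound 3 `COc1nc(C)c(Nc2nc(Cl)cn([C@H](COC(=O)Nc3cccnc3)C3CC3)c2=O)cc1C` carries pyridin-3-yl in place of 2-chlorophenyl on an amide-type nitrogen. Among the measured compounds shown here, this change sits in the same terminal region as the measured step, one bond further out, and no measured step varies the aryl ring itself. For the measured compounds named here, the only step bearing on it is flat, so the expectation for this assay is no change beyond the scatter, with the range widened slightly towards weaker inhibition because the shared data contain nothing on an aromatic ring with a hetero atom in this position.

Compound 3 is estimated at 2 nM, between 0.7 nM and 6 nM. The step this estimate means, a 1.3-fold higher number from compound 2 to compound 3 (0.12 log units; within the scatter), is expected to lie within the scatter.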

Compound 3, half-maximal inhibitory concentration: 10 nM
The estimate for compound 3 lay 5.0-fold (0.70 log units) below the measured number; measured number outside the range, above it.
By their numbers in this assay, from the lowest: compounds 1 and 2 (each within the scatter of the next); then compound 3.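

In this assay, among these compounds, pyridin-3-yl in place of 2-chlorophenyl on the amide-type nitrogen gives a 6.7-fold higher number from compound 2 to compound 3 (0.82 log units; beyond the scatter) and so marks the first change beyond the scatter. The terminal aryl group is therefore not free to vary without cost, which the flat step between the first two compounds (no change at the digits printed from compound 1 to compound 2 (within the scatter)) could not show. The comparison with the phenyl on a carbonyl carbon reads the same (a 6.7-fold higher number from compound 1 to compound 3 (0.82 log units; beyond the scatter)), so compounds 1 and 2 both stand apart from compound 3 by this margin, and nothing shown gives a reason for the loss.

The step to compound 3 removes the chlorine and brings in the ring nitrogen at once, and the compounds shown do not separate these two parts of the change. From the compounds shown here alone, it stays open whether plain phenyl, pyridin-4-yl or 2-chloropyridin-3-yl on the amide-type nitrogen would stay level with compound 2 or fall nearer to compound 3.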